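Taking a Hydroxy Group off Compound 2

This account rests on a few compounds, and the source may have more. Where it says the series, first, only, none or still open, it means among the compounds named here.

In a functional assay on DU-145 cells (Homo sapiens) for inhibition, read by trypan blue exclusion, with a stated time of 96 h (on this read-out lower numbers stand for stronger inhibition of growth and higher numbers for weaker inhibition of growth), compound 1 (`COc1ccc(/C=C(\C(=O)c2ccc(Br)cc2)S(=O)(=O)c2ccc(Br)cc2)cc1`) gives 25000 nM as its result, while compound 2 (`COc1ccc(/C=C(\C(=O)c2ccc(Cl)cc2)S(=O)(=O)c2ccc(Br)cc2)cc1O`) gives 10000 nM as its result. That makes compound 2 the lower of just two numbers, with a gap beyond the scatter. Compound 3 (`COc1ccc(/C=C(\C(=O)c2ccc(Cl)cc2)S(=O)(=O)c2ccc(Br)cc2)cc1`) comes from compound 2 by one change, hydrogen in place of hydroxy on an aromatic carbon, which turns 3-hydroxy-4-methoxyphenyl into 4-methoxyphenyl. Going by the values given here, no measured pair shows this change alone. Compound 1 also carries 4-methoxyphenyl and stands at 25000 nM in this assay, but it differs elsewhere too, so only a modest move towards weaker inhibition of growth is expected. The expected size is an estimated 1.8-fold higher number from compound 2 to compound 3 (0.26 log units; within the scatter) and may not clear the scatter. For compound 3 the estimated value is 18000 nM with an expected range from 7000 nM to 40000 nM as the likely span.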

Compound 3, concentration for 50% growth inhibition: 10000 nM
For compound 3 the middle estimate is 1.8-fold (0.26 log units) above the measured one, within the range that was stated.
By their numbers in this assay, from the lowest: compounds 2 and 3 (each within the scatter of the next); then compound 1.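

In this assay taking the hydroxy group off 3-hydroxy-4-methoxyphenyl gives no change at the digits printed from compound 2 to compound 3 (within the scatter) and so, with the rest of compound 2 kept as it is, this position shows no measurable need for the hydroxy group. Going by these compounds alone, compound 3 also forms a one-place pair with compound 1, chloro in place of bromo on an aromatic carbon, and this pair gives a 2.5-fold lower number from compound 1 to compound 3 (0.40 log units; beyond the scatter) as the only single-place step here beyond the scatter. No accompanying measurement explains either step.

The compounds shown leave open what another group at this position, such as an amine, a carboxylic acid or a longer chain, would do to growth inhibition. They also leave open whether hydrogen and hydroxy would still match if the rest of the molecule were different.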